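Swapping a Nitrile for a Methyl Ester on the Core

This account rests on a few compounds, and the source may have more. Where it says the series, first, only, none or still open, it means among the compounds named here.

In a functional assay on PC-3 cells (Homo sapiens) for inhibition, read by sulforhodamine B assay, with a stated time of 48 h (on this read-out lower numbers stand for stronger inhibition and higher numbers for weaker inhibition), compound 3 `N#C[C@H]1C[C@@H](c2coc3ccc(Cl)cc3c2=O)N(c2ccccc2)O1` gives 41000 nM. Of the two numbers measured this is the larger, yet compound 1 `COC(=O)[C@@]1(C)C[C@@H](c2coc3ccc(F)cc3c2=O)N(c2ccccc2)O1`, which gives 31300 nM in this assay, lies within the usual scatter of it, so the two cannot be told apart. Compound 2 `O=c1c([C@@H]2C[C@H](c3ccccc3)ON2c2ccccc2)coc2ccccc12` gives only a limit of the assay, > 60000 nM; one of the three values shown is such a limit (the limit of > 60000 nM in this assay, at which 1 of the 3 values shown sits). Compound 4 `COC(=O)[C@H]1C[C@@H](c2coc3ccc(Cl)cc3c2=O)N(c2ccccc2)O1` differs from compound 3 in one place: methoxycarbonyl in place of cyano on a saturated ring carbon. Among the compounds with values here, no measured pair shows this exact change, so its size is unknown; since compound 1, which also carries a methoxycarbonyl, gives 31300 nM, the expected step is a 1.2-fold lower number from compound 3 to compound 4 (0.07 log units; within the scatter), within the scatter. Compound 4 is estimated at 35000 nM, ranging from 15000 nM to 80000 nM.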

Compound 4, half-maximal inhibitory concentration: > 60000 nM
Compound 4 ended at the assay's limit (the forecaster's own chance of this, stated with the estimate: 25%); at least 1.7-fold (0.23 log units) between middle value and limit.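

Within the data shown here, this is the first direct reading of methoxycarbonyl against cyano on this saturated ring carbon, next to the ring oxygen, with the rest of the molecule unchanged. In this assay, the change brings no stronger inhibition, giving an at least 1.4-fold higher number from compound 3 to compound 4 (0.16 log units; that floor lies within the scatter). The reading for compound 4 is a limit of the assay, not a number, and it is not the only such reading in the set: the limit of > 60000 nM in this assay, at which 2 of the 4 values shown sit.

As far as these compounds go, how far compound 4 truly lies from compound 3 stays open, since only a floor can be read. Also open, from the compounds shown here alone, is whether a carboxylic acid or an amine on this ring carbon would give a measurable number.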